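Moving the chlorine on the pyridine amide of compound 2

A few compounds are considered here, and "the series" means these few. Any claim that something is new, unique, unknown or untested is made for them only; others in the source may bear on it.

Measured so far:
compound 1 `Cn1cc(-c2cnc(N)c(Oc3ccc(C(=O)Nc4ccc(Cl)cc4)cc3)n2)cn1` — 3440 nM
compound 2 `Cn1cc(-c2cnc(N)c(Oc3ccc(C(=O)Nc4cccc(Cl)n4)cc3)n2)cn1` — 38200 nM

Both compounds were tested in a functional assay on HeLa cells (Homo sapiens) for inhibition, read by MTT assay, with a stated time of 72 h; a lower number here means a stronger inhibitor, a higher number a weaker inhibitor. Among the compounds with values here, compound 2 gives the highest of the two numbers; its nearest neighbour is compound 1, and the single step between them, an 11-fold higher number from compound 1 to compound 2 (1.05 log units; beyond the scatter), is large. Compound 3 `Cn1cc(-c2cnc(N)c(Oc3ccc(C(=O)Nc4cc(Cl)ccn4)cc3)n2)cn1` has not yet been measured. It differs from compound 2 only in the group on the amide-type nitrogen: 4-chloropyridin-2-yl in place of 6-chloropyridin-2-yl on an amide-type nitrogen.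

Within the data shown here, only one measured step exists, and it exchanges a chlorophenyl ring for a chloropyridine ring, not one chloropyridine for another. It shows that this part of the molecule can move the result a great deal, but it gives no direction for the present change. With nothing closer to lean on, the expectation for compound 3 is a number near that of compound 2, with a wide range that allows a return toward compound 1 as well as a further loss; the estimated step is a 1.9-fold lower number from compound 2 to compound 3 (0.28 log units; within the scatter). Compound 3 is therefore expected to give about 20000 nM, between 5000 nM and 80000 nM.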

Compound 3, half-maximal inhibitory concentration: 40800 nM
For compound 3 the middle estimate is 2.0-fold (0.31 log units) below the measured one; the measured number falls inside the stated range.
By their numbers in this assay, from the lowest: compound 1; then compounds 2 and 3 (each within the scatter of the next).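

In this assay, moving the chlorine from 6-chloropyridin-2-yl to 4-chloropyridin-2-yl on the amide-type nitrogen gives a 1.1-fold higher number from compound 2 to compound 3 (0.03 log units; within the scatter), so for these two placements the position of the chlorine on the pyridine ring makes no visible difference. The large gap to the 4-chlorophenyl compound also appears with the second chloropyridine, as a 12-fold higher number from compound 1 to compound 3 (1.07 log units; beyond the scatter), and this matches an 11-fold higher number from compound 1 to compound 2 (1.05 log units; beyond the scatter), so it is no longer tied to one chlorine placement. Nothing measured here explains why the two chloropyridine compounds match or why both give higher numbers than compound 1.

The compounds shown leave open whether a pyridin-2-yl ring with no chlorine, or with a methoxy group or an amine in its place, would stay near these numbers or move back toward compound 1. They also leave open whether a plain phenyl or a 4-fluorophenyl ring on the amide-type nitrogen would give a number close to that of compound 1, 3440 nM.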